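The compounds below may be only part of what the source reports. "The series", "measured", "known", "first", "only" and "open" are said of these compounds alone.

Measured in a functional assay on MGC-803 cells (Homo sapiens) for antiproliferative activity, read by MTT assay, with a stated time of 48 h; on this read-out higher numbers stand for weaker inhibition and lower numbers for stronger inhibition:
- compound 1 `COc1cc(N(Cc2ccc(C)cc2)C(=O)CSc2nc3ccccc3s2)cc(OC)c1OC`: 54200 nM
- compound 2 `COc1ccc(CN(C(=O)CSc2nc3ccccc3s2)c2cc(OC)c(OC)c(OC)c2)cc1N=[N+]=[N-]`: 187 nM
- compound 3 `COc1ccc(CN(C(=O)CSc2nc3ccccc3s2)c2cc(OC)c(OC)c(OC)c2)cc1`: 163 nM

Compound 3 shares the low end of these numbers, with a 1.1-fold lower number from compound 2 to compound 3 (0.06 log units; within the scatter), and stands far from the remaining value, with a 330-fold lower number from compound 1 to compound 3 (2.52 log units; beyond the scatter). Compound 4 `COc1cc(N(Cc2ccccc2)C(=O)CSc2nc3ccccc3s2)cc(OC)c1OC` turns 4-methoxybenzyl into benzyl, hydrogen in place of methoxy on an aromatic carbon. The closest evidence is the methyl-to-methoxy step at that same place, a 330-fold lower number from compound 1 to compound 3 (2.52 log units; beyond the scatter). The step of a 290-fold lower number from compound 1 to compound 2 (2.46 log units; beyond the scatter) also carries methoxy there, but it changes azido as well. Going by the values given here, no measured compound has hydrogen at this place, so the size is uncertain. A large move towards a higher number is expected, probably short of the full methyl step: a 31-fold higher number from compound 3 to compound 4 (1.49 log units; beyond the scatter). For compound 4 the estimated value is 5000 nM, with an expected range of 800 nM to 40000 nM.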

Compound 4, half-maximal inhibitory concentration: 44300 nM
Compound 4: middle estimate off by 8.9-fold (0.95 log units), on the low side; measured number outside the range, above it.
By their numbers in this assay, from the lowest: compounds 3 and 2 (each within the scatter of the next); then compounds 4 and 1 (each within the scatter of the next).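

In this assay, taking the methoxy off the 4-methoxybenzyl group moves the number sharply upward (a 270-fold higher number from compound 3 to compound 4 (2.43 log units; beyond the scatter)), and the step from the azido-bearing compound is of similar size (a 240-fold higher number from compound 2 to compound 4 (2.37 log units; beyond the scatter)). Hydrogen and methyl on this aromatic carbon cannot be told apart (a 1.2-fold lower number from compound 1 to compound 4 (0.09 log units; within the scatter)), so among these compounds only those carrying methoxy there reach the low numbers. No available measurement accounts for this. As far as these compounds go, whether a hydroxyl, an ethoxy or an amine on that carbon would also give low numbers remains open.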